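From thiophen-2-yl to naphthalen-1-yl on the shared core

A few compounds are considered here, and "the series" means these few. Any claim that something is new, unique, unknown or untested is made for them only; others in the source may bear on it.

Three compounds that differ in a single group on the shared core have been measured in a functional assay for inhibition, with Homo sapiens as the target; on this read-out lower numbers stand for tighter binding and higher numbers for weaker binding. There, compound 1 `O=C(O)CC/C=C\CC1COC(c2ccccc2Cl)OC1c1cccnc1`, with 2-chlorophenyl, gives 759 nM. Compound 2 `O=C(O)CC/C=C\CC1COC(c2ccc(C(F)(F)F)cc2)OC1c1cccnc1`, with 4-(trifluoromethyl)phenyl, gives 1780 nM. Compound 3 `O=C(O)CC/C=C\CC1COC(c2cccs2)OC1c1cccnc1`, with thiophen-2-yl, gives 1000 nM, which lies within the scatter of both others: a 1.3-fold higher number from compound 1 to compound 3 (0.12 log units; within the scatter), and a 1.8-fold lower number from compound 2 to compound 3 (0.25 log units; within the scatter).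

Compound 4 `O=C(O)CC/C=C\CC1COC(c2cccc3ccccc23)OC1c1cccnc1` carries naphthalen-1-yl in place of thiophen-2-yl on a saturated ring carbon, between two ring oxygen atoms: naphthalen-1-yl in place of thiophen-2-yl on a saturated ring carbon. Within the data shown here, no measured compound carries naphthalen-1-yl, so the three steps at this same carbon are the only guide. Among them, only one exceeds the scatter, and it is modest: a 2.3-fold higher number from compound 1 to compound 2 (0.37 log units; beyond the scatter). Compound 3 itself differs from compound 1 by no more than the scatter, at a 1.3-fold higher number from compound 1 to compound 3 (0.12 log units; within the scatter). On these three compounds, a change of group at this carbon has moved the number only slightly, so no step beyond the scatter is expected in this assay. The expected step is a 1.2-fold lower number from compound 3 to compound 4 (0.07 log units; within the scatter), an estimate that stays within the scatter. The estimated value for compound 4 is 850 nM, with an expected range of 300 nM to 2400 nM.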

Compound 4, dissociation constant: 631 nM
The estimate for compound 4 lay 1.3-fold (0.13 log units) above the measured number, within the range that was stated.
By their numbers in this assay, from the lowest: compounds 4, 1, 3 and 2 (each within the scatter of the next, the first and the last beyond it).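

In this assay, naphthalen-1-yl, with 10 heavy atoms and two six-membered aromatic rings, stands at this saturated ring carbon within the scatter of the smaller thiophen-2-yl (a 1.6-fold lower number from compound 3 to compound 4 (0.20 log units; within the scatter)) and of 2-chlorophenyl (a 1.2-fold lower number from compound 1 to compound 4 (0.08 log units; within the scatter)), so the larger aromatic system is accepted here without a step beyond the scatter. Among these compounds, the only new step beyond the scatter is a modest one (a 2.8-fold lower number from compound 2 to compound 4 (0.45 log units; beyond the scatter)), and it adds a second such step involving compound 2, with 4-(trifluoromethyl)phenyl, while compound 3 remains within the scatter of all three other compounds. Nothing available explains why these four groups give numbers so close to one another.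

From the compounds shown here alone, all four groups at this carbon are aromatic, so it remains open whether cyclohexyl or a plain butyl chain would give a number in the same range. The pyridin-3-yl group and the 5-carboxypent-2-en-1-yl group stay the same throughout, which leaves open how the number would respond to a phenyl group in place of the pyridin-3-yl group or to a longer chain ending in the carboxylic acid.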